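The source may report more compounds than this note shows. Statements on the series, on what has been measured and on what is new or still open speak of the compounds shown alone.

Of the compounds shown here, three with a shared core have been measured in a functional assay on A549 cells (Homo sapiens) for antiproliferative activity, read by MTT assay, with a stated time of 48 h; a lower number here means a stronger inhibitor, a higher number a weaker inhibitor. Compound 1 `CCCCOc1ccc(C(=O)/C=C/c2c(/C=C/c3ccc(OC)cc3)cc(OC)cc2OC)cc1` gives 8.7 ug/mL, compound 2 `COc1ccc(/C=C/c2cc(OC)cc(OC)c2/C=C/C(=O)c2cccc(Br)c2)cc1` gives 8.1 ug/mL, and compound 3 `CCCCCCOc1ccc(C(=O)/C=C/c2c(/C=C/c3ccc(OC)cc3)cc(OC)cc2OC)cc1` gives 8.4 ug/mL. Compound 3 therefore stands level with the other two, and its gaps to both lie within the scatter of repeated measurements.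

The next compound, compound 4 `COc1ccc(/C=C/c2cc(OC)cc(OC)c2/C=C/C(=O)c2ccc(N)cc2)cc1`, puts amino in place of hexyloxy on an aromatic carbon, para to a large group: amino in place of hexyloxy on an aromatic carbon. Among the measured compounds shown here, two measured steps bear on this change, as both alter the same end of the molecule. Placing ethyl in place of hydrogen on the saturated chain gave a 1.0-fold lower number from compound 1 to compound 3 (0.02 log units; within the scatter), and placing 3-bromophenyl in place of 4-butoxyphenyl gave a 1.1-fold lower number from compound 1 to compound 2 (0.03 log units; within the scatter). Neither step goes beyond the scatter, so these three compounds give no sign that this end of the molecule moves the number in this assay. None of them carries an amino group, however, so the evidence is indirect and the range must stay wide.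

The expected result is a 1.1-fold lower number from compound 3 to compound 4 (0.02 log units; within the scatter), which means no change beyond the scatter in either direction. For compound 4 the estimated value is 8 ug/mL, with an expected range of 3.5 ug/mL to 18 ug/mL.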

Compound 4, half-maximal inhibitory concentration: 3.8 ug/mL
For compound 4 the middle estimate is 2.1-fold (0.32 log units) above the measured one; measured number inside the range.
By their numbers in this assay, from the lowest: compound 4; then compounds 2, 3 and 1 (each within the scatter of the next).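

In this assay, this end of the molecule turns out to matter, although the earlier changes here stayed within the scatter: amino in place of hexyloxy on an aromatic carbon, para to a large group, gives a 2.2-fold lower number from compound 3 to compound 4 (0.34 log units; beyond the scatter) and amino in place of butoxy gives a 2.3-fold lower number from compound 1 to compound 4 (0.36 log units; beyond the scatter) as well. The comparison with the bromine-bearing compound points the same way, since 4-aminophenyl in place of 3-bromophenyl gives a 2.1-fold lower number from compound 2 to compound 4 (0.33 log units; beyond the scatter) and so sets compound 4 apart as the strongest of the four, though all three steps are modest and only just clear the scatter. No measurement shown explains why the number falls with this change.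

The compounds shown cannot separate what the amino group adds from what is lost with the alkoxy chain, as the chain goes and the amino group arrives in the same step. A hydroxyl or methoxy group on the same aromatic carbon, or a dimethylamino or acetamido group, would help to tell these two readings apart.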